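A Second Methoxy Group on the Core of Compound 3

The source may report more compounds than this note shows. Statements on the series, on what has been measured and on what is new or still open speak of the compounds shown alone.

In an assay on cell membranes for binding affinity to Neuronal acetylcholine receptor; alpha4/beta2 (Rattus norvegicus), read by radioligand binding (on this read-out higher numbers stand for weaker inhibition and lower numbers for stronger inhibition), compound 3 `COc1cncc(N2CCCNCC2)c1` gives 1.9 nM, the second highest of three numbers; compound 2 `OCCOc1cncc(N2CCCNCC2)c1` gives 1.8 nM and compound 1 `c1cncc(-c2cncc(N3CCCNCC3)c2)c1` gives 2.8 nM. The step of a 1.5-fold lower number from compound 1 to compound 3 (0.17 log units; within the scatter), the step of a 1.1-fold higher number from compound 2 to compound 3 (0.02 log units; within the scatter) and the step of a 1.6-fold lower number from compound 1 to compound 2 (0.19 log units; within the scatter) all lie within the scatter. Compound 4 `COc1cc(N2CCCNCC2)cnc1OC` differs from compound 3 by methoxy in place of hydrogen on an aromatic carbon. Among the measured compounds shown here, no measured step adds a group in this way; the three steps that exist all exchange one substituent for another and none moves the number beyond the scatter. The step from compound 3 to compound 4 is therefore expected to be a 1.6-fold higher number from compound 3 to compound 4 (0.20 log units; within the scatter), within the scatter. Compound 4 is estimated at 3 nM in this assay, with a range from 1 nM to 10 nM.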

Compound 4, half-maximal inhibitory concentration: 170 nM
The estimate for compound 4 lay 57-fold (1.75 log units) below the measured number, and the stated range ends below it.
By their numbers in this assay, from the lowest: compounds 2, 3 and 1 (each within the scatter of the next); then compound 4.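

On the aromatic carbon next to the ring nitrogen and ortho to a methoxy group, adding methoxy in place of hydrogen gives in this assay an 89-fold higher number from compound 3 to compound 4 (1.95 log units; beyond the scatter), whereas every exchange among compound 1, compound 2 and compound 3 stayed within the scatter. Among the compounds shown here, the read-out is therefore sensitive to this single change at this carbon, something the earlier compounds could not show. Nothing available explains the step.

Going by these compounds, what a fluorine atom, an amine or a longer ether chain would give on this carbon remains open. So does whether the step depends on the methoxy group already ortho to it.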